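Methyl removal and cytotoxicity limits in a fused-ring series

The source may hold more compounds than are shown below. What is called first, only, known or untested is meant among the compounds shown, and "the series" means these compounds.

Compound 1 `COC(=O)c1c[nH]c2cc(OCCOc3ccccc3)ccc2c1=O` and compound 2 `COC(=O)c1c[nH]c2cc(OCCOc3ccccc3)c(C)cc2c1=O` share one core, while compound 3 `CCCCc1cc2c(=O)c(Br)c(C)[nH]c2cc1OCCOc1ccccc1` carries another; the difference between the two cores is not broken down here. In an ADME assay on J774 cells (Mus musculus) for cytotoxicity (on this read-out higher numbers stand for an effect only at larger amounts of compound and lower numbers for an effect already at smaller amounts), compound 1 gives > 20000 nM, which is a limit of the assay and not a number. In this assay compound 2 gives > 20000 nM, again a limit. In this assay compound 3 gives > 10000 nM, likewise a limit. The change from compound 2 to compound 1 is hydrogen in place of methyl on an aromatic carbon and the step that the two limits leave unreadable from compound 2 to compound 1 cannot be read because the limit of > 20000 nM in this assay, at which 2 of the 3 values shown sit, holds both ends. Compound 4 `CCCCc1cc2c(=O)c(Br)c[nH]c2cc1OCCOc1ccccc1` is not yet measured; it differs from compound 3 by hydrogen in place of methyl on an aromatic carbon, the same kind of change, though here the place lies in a six-membered aromatic ring with one nitrogen, next to the ring nitrogen and ortho to a bromo group, rather than in a ring of carbon only, ortho to a large group. Beside the earlier step, a step that the limit leaves unreadable from compound 3 to compound 4 in this assay is expected, resting on compound 3 sitting at the limit of > 10000 nM in this assay, at which 1 of the 3 values shown sits, and on the earlier pair resting at the limit of > 20000 nM in this assay, at which 2 of the 3 values shown sit. Compound 4 is therefore estimated at 30000 nM, with an expected range from 10000 nM to 100000 nM, most likely reported again only as a limit.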

Compound 4, half-maximal effective concentration: 8070 nM
Beside the measured number, compound 4's estimate is 3.7-fold (0.57 log units) above it; measured number outside the range, below it.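

On the core of compound 3, hydrogen in place of methyl on an aromatic carbon gives an at least 1.2-fold lower number from compound 3 to compound 4 (0.09 log units; that floor lies within the scatter) in this assay, so the step may be larger than its floor, but that floor does not clear the scatter. The same change on the core of compound 1 cannot be read, and the change therefore cannot be compared between the two cores, because both ends of that earlier step sit at one limit: the limit of > 20000 nM in this assay, at which 2 of the 4 values shown sit. The result shows one bounded step on one core only and does not show that the change behaves alike or differently on the other core, where the place does not lie on a six-membered aromatic ring with 1 nitrogen, next to the ring nitrogen and ortho to a bromo group.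

Left open is how an amine, a carboxylic acid or a longer chain at that carbon of compound 4 would read in this assay. Also open, on these data alone, is the actual size of the step, since compound 3 stands only as a limit.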